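The source may report more compounds than this note shows. Statements on the series, on what has been measured and on what is new or still open speak of the compounds shown alone.

Of the compounds shown here, three have been tested in an ADME assay on Vero cells (Chlorocebus sabaeus) for cytotoxicity, with a stated time of 72 h; on this read-out higher numbers stand for lower toxicity in this test and lower numbers for higher toxicity in this test. Compound 1 `CCCCCCCNc1ccc(C(=O)C2CC2c2ccc(Cl)cc2)cc1` gives 398 ug/mL, compound 2 `CN(C)CCCNc1ccc(C(=O)C2CC2c2ccc(Cl)cc2)cc1` gives 15.8 ug/mL, and compound 3 `CCCCCCCCNc1ccc(C(=O)C2CC2c2ccc(Cl)cc2)cc1` gives 214 ug/mL. Compound 3 thus stands second highest of the three: compound 1 is its nearest neighbour, with a 1.9-fold lower number from compound 1 to compound 3 (0.27 log units; within the scatter), while compound 2 is furthest away, with a 14-fold higher number from compound 2 to compound 3 (1.13 log units; beyond the scatter). Within the data shown here, the one change that moved the numbers strongly was a 25-fold lower number from compound 1 to compound 2 (1.40 log units; beyond the scatter).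

Compound 4 `O=C(c1ccc(NCCn2ccnc2)cc1)C1CC1c1ccc(Cl)cc1` has not yet been measured. It differs from compound 3 in one place: 1H-imidazol-1-yl in place of hexyl on a saturated chain carbon, two bonds along the chain from a nitrogen on an aromatic ring. As in the earlier pair, part of a plain chain is swapped for a group that carries nitrogen atoms. The two steps that bear on this, a 14-fold higher number from compound 2 to compound 3 (1.13 log units; beyond the scatter) and a 25-fold lower number from compound 1 to compound 2 (1.40 log units; beyond the scatter), were both large, and in both the plain chain gave the higher number. A drop beyond the scatter is therefore expected for compound 4 in this assay, though the entering group is a ring rather than the open dimethylamino, so the size remains uncertain. The expected step is a 3.6-fold lower number from compound 3 to compound 4 (0.55 log units; beyond the scatter). Compound 4 is estimated at 60 ug/mL, with a likely range from 20 ug/mL to 200 ug/mL.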

Compound 4, half-maximal cytotoxic concentration: 243 ug/mL
Estimate against measurement, compound 4: 4.1-fold (0.61 log units) below; measured number above the stated range.
By their numbers in this assay, from the lowest: compound 2; then compounds 3, 4 and 1 (each within the scatter of the next).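

In this assay, a group with nitrogen atoms at this place on the chain does not by itself lower the number: 1H-imidazol-1-yl in place of hexyl leaves it within the scatter (a 1.1-fold higher number from compound 3 to compound 4 (0.06 log units; within the scatter)), and the comparison with the plain heptyl-bearing chain also stays within the scatter (a 1.6-fold lower number from compound 1 to compound 4 (0.21 log units; within the scatter)). Among these four compounds, the low number stands with compound 2 alone, which carries dimethylamino and lies well apart from the imidazole compound (a 15-fold higher number from compound 2 to compound 4 (1.19 log units; beyond the scatter)). Nothing available here explains why these two nitrogen-bearing groups part ways.

Still open, on these data alone, is whether the gap follows the group itself or the chain carrying it, since dimethylamino and 1H-imidazol-1-yl sit on chains of different length here. As far as these compounds go, how a morpholine ring or a carboxylic acid at this place would read also remains unknown.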